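The compounds below may be only part of what the source reports. "The series", "measured", "known", "first", "only" and "open" are said of these compounds alone.

Two compounds share one core and differ in the groups on the aromatic ring. Compound 1 `CCN(CC)c1ccc(/C=C2\C(=O)N(C3CCCCC3)C(=S)N2C)cc1` carries a diethylamino group; in an assay on isolated protein for inhibition of NADPH oxidase 4 (Homo sapiens), read by chemiluminescence, in the presence of a further agent that is not named here (on this read-out higher numbers stand for weaker inhibition and lower numbers for stronger inhibition), compound 1 gives 6350 nM. Compound 2 `CN1C(=S)N(C2CCCCC2)C(=O)/C1=C\c1ccc(N(C)C)cc1O` carries a dimethylamino group and a hydroxy group; in this assay compound 2 gives 2350 nM, the lowest of the two numbers, and the gap to compound 1 lies beyond the scatter. Compound 3 `CCN(CC)c1ccc(/C=C2\C(=O)N(C3CCCCC3)C(=S)N2C)c(O)c1` keeps the hydroxy group and makes one change: diethylamino in place of dimethylamino on an aromatic carbon. For the measured compounds named here, no measured pair shows this exchange alone, so the step is expected to be small, within the scatter, in either direction. Compound 3 is estimated at 2500 nM, with a range from 900 nM to 7000 nM, the expected step being a 1.1-fold higher number from compound 2 to compound 3 (0.03 log units; within the scatter).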

Compound 3, half-maximal inhibitory concentration: 2350 nM
Estimate against measurement, compound 3: 1.1-fold (0.03 log units) above; low and high end bracket the measured number.
By their numbers in this assay, from the lowest: compounds 2 and 3 (each within the scatter of the next); then compound 1.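

In this assay, diethylamino in place of dimethylamino at this position, para to a large group, gives no change at the digits printed from compound 2 to compound 3 (within the scatter), so with the hydroxy group present, the larger amino group makes no measurable difference. For the compounds shown here, the new compound also gives the first one-place reading of the hydroxy group: hydroxy in place of hydrogen gives a 2.7-fold lower number from compound 1 to compound 3 (0.43 log units; beyond the scatter). Nothing available here explains either step. Still open, on these data alone, is whether the amino exchange behaves the same way without the hydroxy group. As far as these compounds go, it is also open how a methoxy group in the hydroxy group's place, or a pyrrolidine in the amino group's place, would read.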